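The source may hold more compounds than are shown below. What is called first, only, known or untested is meant among the compounds shown, and "the series" means these compounds.

In a functional assay on OVCAR-3 cells (Homo sapiens) for activation, with a stated time of 24 h (a higher number here means that more compound is needed for the effect, a lower number that less compound is needed), compound 1, whose structure is `O=C(Nc1cccc(S(=O)(=O)N2CCCC2)c1)c1cccnc1N1CCC2(CC1)CC2`, gives 5460 nM. Two other compounds in the set have been measured in this assay. Compound 2, with structure `COc1ccc(C(=O)Nc2cccc(S(=O)(=O)C3CCCC3)n2)c(N2CCC3(CC2)CC3)c1`, gives 2660 nM, and compound 3, with structure `O=C(Nc1cccc(S(=O)(=O)C2CCCC2)c1)c1cccnc1N1CCC(F)(F)CC1`, gives 4630 nM. Compound 1 thus carries the highest number of the three; its gap to compound 3 lies within the scatter, while its gap to compound 2 lies beyond it. Within the data shown here, no pair of measured compounds differs in a single place, so no measured step guides the next change.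

Compound 4, with structure `CC(C)S(=O)(=O)c1cccc(NC(=O)c2cccnc2N2CCC3(CC2)CC3)c1`, has not yet been measured in this assay. Its difference from compound 1 is isopropyl in place of pyrrolidin-1-yl on a sulfonyl sulfur. The group that enters has no ring and three heavy atoms in place of a five-membered ring with one hetero atom.

Among the measured compounds shown here, with no measured step of this kind, the account expects the step of a 1.3-fold lower number from compound 1 to compound 4 (0.11 log units; within the scatter) to stay small, at most a modest move in either direction. Compound 4 is estimated at 4200 nM in this assay, with a range from 1500 nM to 12000 nM.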

Compound 4, half-maximal effective concentration: 4290 nM
The estimate for compound 4 lay 1.0-fold (0.01 log units) below the measured number, and the stated range covers the measured number.
By their numbers in this assay, from the lowest: compounds 2, 4, 3 and 1 (each within the scatter of the next, the first and the last beyond it).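

The first single change measured on this sulfonyl sulfur, isopropyl in place of pyrrolidin-1-yl, gives a 1.3-fold lower number from compound 1 to compound 4 (0.10 log units; within the scatter) in this assay. On a sulfonyl sulfur whose other neighbour is an aromatic carbon, the five-membered ring and its nitrogen can therefore be replaced by a group with no ring and three carbons without a step beyond the scatter. No available evidence bears on what lies behind this result.

Compounds 2 and 3 also carry a ring on the sulfonyl sulfur, but they differ from compound 4 in more than one place, so they cannot be read against this step. On these data alone, whether a morpholin-4-yl ring, a dimethylamino group or a longer alkyl chain at this place would give a step beyond the scatter remains open.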